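Amine substituent on the shared core: compound 3 outlook

The source may report more compounds than this note shows. Statements on the series, on what has been measured and on what is new or still open speak of the compounds shown alone.

The series varies the group on a nitrogen on an aromatic ring of the shared core, the rest being held constant. Compound 1 `OCCCNc1nc(-c2ccccc2)nc2c1nnn2Cc1ccccc1` carries 3-hydroxypropyl there; in an assay on isolated protein for binding affinity to adenosine receptor A1 (Bos taurus) (on this read-out lower numbers stand for stronger inhibition and higher numbers for weaker inhibition), compound 1 gives 21400000 nM. Compound 2 `OC1CCC(Nc2nc(-c3ccccc3)nc3c2nnn3Cc2ccccc2)CC1` carries 4-hydroxycyclohexyl instead; in this assay compound 2 gives 2700000 nM. Going by the values given here, this is the lowest of the two numbers measured so far, the only other being compound 1, and the step of a 7.9-fold lower number from compound 1 to compound 2 (0.90 log units; beyond the scatter) is the single measured step that bears on the next change. Compound 3 `CNc1nc(-c2ccccc2)nc2c1nnn2Cc1ccccc1` differs from compound 2 by methyl in place of 4-hydroxycyclohexyl on a nitrogen on an aromatic ring. Among the compounds with values here, no measured pair covers the loss of the ring and of the hydroxyl together, so the expectation rests on that one step, which places the hydroxycyclohexyl group at the better end of what has been measured. Removing it is expected to move the number upward by a step at least as large as the one seen, so compound 3 is expected at 25000000 nM (range 5000000 nM to 120000000 nM), an estimated step of a 9.3-fold higher number from compound 2 to compound 3 (0.97 log units; beyond the scatter) in this assay.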

Compound 3, inhibition constant: 353000000 nM
For compound 3 the middle estimate is 14-fold (1.15 log units) below the measured one, outside the stated range (above it).
By their numbers in this assay, from the lowest: compound 2; then compound 1; then compound 3.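

In this assay, going by these compounds alone, the position proves far more sensitive than the single earlier step suggested: replacing 4-hydroxycyclohexyl with methyl gives (a 130-fold higher number from compound 2 to compound 3 (2.12 log units; beyond the scatter)), a much larger change than the one between the two hydroxylated groups (a 7.9-fold lower number from compound 1 to compound 2 (0.90 log units; beyond the scatter)). The open chain also keeps an advantage over methyl (a 16-fold higher number from compound 1 to compound 3 (1.22 log units; beyond the scatter)), so compound 1 now falls between the other two, and both hydroxyl-bearing groups give lower numbers than methyl, with no listed compound going against that order. No measurement on hand accounts for these steps.

The three compounds leave open whether the lower numbers follow the hydroxyl, the carbon framework or both, as the change from 4-hydroxycyclohexyl to methyl removes the ring and the hydroxyl together, and the change from 3-hydroxypropyl to methyl removes the chain and the hydroxyl together. Plain cyclohexyl and plain propyl on the same nitrogen would separate these contributions, while a 4-aminocyclohexyl group would show whether an amine can stand in for the hydroxyl on the ring.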